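The compounds below may be only part of what the source reports. "The series", "measured", "known", "first", "only" and "open" are said of these compounds alone.

Measured so far:
compound 1 `CC(C)c1c(C(=O)N(C)Cc2ccccc2)nn(-c2ccc(F)cc2)c1CC[C@@H](O)C[C@@H](O)CC(=O)O`: 6.2 nM in an assay on microsomes from liver for inhibition of 3-hydroxy-3-methylglutaryl-coenzyme A reductase (Rattus norvegicus); on this read-out lower numbers stand for stronger inhibition and higher numbers for weaker inhibition
compound 2 `CC(C)c1c(C(=O)N2CCC[C@H](c3ccccc3)C2)nn(-c2ccc(F)cc2)c1CC[C@@H](O)C[C@@H](O)CC(=O)O`: 2.1 nM in this assay

Among the compounds with values here, compound 2 holds the lower of the two numbers in this assay; the one measured step, a 3.0-fold lower number from compound 1 to compound 2 (0.47 log units; beyond the scatter), separates them. Compound 3 `CC(C)c1c(C(=O)N(C)Cc2cccc(F)c2)nn(-c2ccc(F)cc2)c1CC[C@@H](O)C[C@@H](O)CC(=O)O` is reached from compound 2 by (3-fluorobenzyl)(methyl)amino in place of 3-phenylpiperidin-1-yl on a carbonyl carbon. Within the data shown here, the only step that bears on this is a 3.0-fold lower number from compound 1 to compound 2 (0.47 log units; beyond the scatter), which runs the opposite way; compound 3 differs from compound 1 only in carrying (3-fluorobenzyl)(methyl)amino rather than benzyl(methyl)amino, a change with no measured step. The move is therefore expected to largely undo that gain, giving a 2.6-fold higher number from compound 2 to compound 3 (0.42 log units; beyond the scatter). Compound 3 is estimated at 5.5 nM in this assay, within 2.5 nM to 12 nM.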

Compound 3, half-maximal inhibitory concentration: 4.1 nM
Compound 3: middle estimate off by 1.3-fold (0.13 log units), on the high side, within the range that was stated.
By their numbers in this assay, from the lowest: compounds 2, 3 and 1 (each within the scatter of the next, the first and the last beyond it).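

Fluoro in place of hydrogen on an aromatic carbon gives a 1.5-fold lower number from compound 1 to compound 3 (0.18 log units; within the scatter) in this assay and so does not separate the fluorinated compound from its parent. (3-Fluorobenzyl)(methyl)amino in place of 3-phenylpiperidin-1-yl on the carbonyl carbon gives a 2.0-fold higher number from compound 2 to compound 3 (0.29 log units; within the scatter) and so, unlike compound 1, compound 3 is not separated from compound 2. Nothing available accounts for either step.

Going by these compounds, whether chloro or methoxy in place of the fluoro would give a step beyond the scatter remains open. So does the effect of ethyl in place of the methyl on the amide nitrogen.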